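A Sulfone Arm in Place of an Iodoalkene

The source may report more compounds than this note shows. Statements on the series, on what has been measured and on what is new or still open speak of the compounds shown alone.

Of the compounds shown here, three have been tested in an ADME assay on L1210/0 cells (Mus musculus) for cytotoxicity, with a stated time of 48 h; a lower number here means a stronger inhibitor, a higher number a weaker inhibitor. Compound 1 `O=c1[nH]c(=O)n([C@H]2C[C@H](O)[C@@H](CO)O2)cc1/C=C/I` gives 63900 nM, which places it second highest of the three numbers. The nearest neighbour is compound 3 `Nc1ccn([C@@H]2O[C@H](CO)[C@H](F)[C@@H]2O)c(=O)n1`, which in this assay gives 159000 nM, and the furthest is compound 2 `CC(=O)OCCOCn1cnc2c(=S)[nH]c(N)nc21`, which in this assay gives 3200 nM. Within the data shown here, none of these three differ in only one place, so no single step between measured compounds can be read off.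

The next compound, compound 4 `CS(=O)(=O)Cc1cn([C@H]2C[C@H](O)[C@@H](CO)O2)c(=O)[nH]c1=O`, differs from compound 1 in one place: (methylsulfonyl)methyl in place of 2-iodoethenyl on an aromatic carbon. The iodine-bearing alkene on the six-membered aromatic ring is thus replaced by a sulfone-bearing chain.

Among the measured compounds shown here, with no comparable step in hand, the expectation rests on compound 1 alone, whose 63900 nM already sits toward the weak end of the range. The step from compound 1 to compound 4 is expected to be small, a 1.6-fold higher number from compound 1 to compound 4 (0.19 log units; within the scatter), and not clearly beyond the scatter. Compound 4 is therefore estimated at 100000 nM in this assay, with a range from 30000 nM to 400000 nM.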

Compound 4, half-maximal inhibitory concentration: > 200000 nM
Compound 4 gave a limit, no number; the forecaster's own chance of this, stated with the estimate: 30%; middle value at least 2.0-fold (0.30 log units) away from the limit.
By their numbers in this assay, from the lowest: compound 2; then compound 1; then compound 3. At a limit, above all of these: compound 4.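

At this aromatic carbon of the shared core, (methylsulfonyl)methyl in place of 2-iodoethenyl gives an at least 3.1-fold higher number from compound 1 to compound 4 (0.49 log units; beyond the scatter) in this assay, the only comparison shown so far between two compounds that differ in one place. It shows that the group at this position matters, with the change moving toward a weaker inhibitor. In the same assay, compound 4 gives a limit and not a number, so the step has a known direction and a known minimum but no known full size: the limit of > 200000 nM in this assay, at which 1 of the 4 values shown sits.

As far as these compounds go, what stays open is whether the change comes from losing 2-iodoethenyl or from gaining (methylsulfonyl)methyl, since one swap does both at once. An ethyl group, an amine or a carboxylic acid at this carbon would help separate the two.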